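Exchanging a benzyl group with cytotoxicity at the limit

The compounds below may be only part of what the source reports. "The series", "measured", "known", "first", "only" and "open" are said of these compounds alone.

Compound 1: `Cc1ccc2[nH]c(=O)c(CN(Cc3ccc(OCCO)cc3)Cc3ccc(C(C)(C)C)cc3)cc2c1`; in a toxicity assay on MDCK cells (Canis lupus familiaris) for cytotoxicity, read by crystal violet staining, with a stated time of 48 h (on this read-out higher numbers stand for lower toxicity in this test and lower numbers for higher toxicity in this test), compound 1 gives > 5000 nM, which is a limit of the assay and not a number.
Compound 2: `Cc1ccc2[nH]c(=O)c(CN(Cc3ccc(C(C)(C)C)cc3)[C@@H](C)c3ccc(F)cc3)cc2c1`; in this assay compound 2 gives > 5000 nM, again a limit of the assay rather than a number.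

Within the data shown here, compound 2 therefore stands at the upper edge of what this assay can report, and its one measured neighbour, compound 1, stands at the same edge. The step that the two limits leave unreadable from compound 1 to compound 2 is consequently not readable in either direction, as the limit of > 5000 nM in this assay, at which 2 of the 2 values shown sit, makes plain.

Compound 3, `Cc1ccc2[nH]c(=O)c(CN(Cc3ccc(C(C)(C)C)cc3)Cc3ccc(N(C)C)c(Cl)c3)cc2c1`, has not yet been measured. It differs from compound 2 by 3-chloro-4-(dimethylamino)benzyl in place of 1-(4-fluorophenyl)ethyl on an amine nitrogen. Among the measured compounds shown here, no measured step bears directly on this change, and the single step that exists, a step that the two limits leave unreadable from compound 1 to compound 2, gives no size to lean on. With both known values sitting at the limit, the expectation for compound 3 is that it, too, will most likely be reported only as a limit, with no shift beyond the scatter readable from compound 2.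

On that basis compound 3 is estimated at 6000 nM in this assay, within the range 2500 nM to 15000 nM. The expected step from the measured neighbour is a step that the limit leaves unreadable from compound 2 to compound 3.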

Compound 3, half-maximal cytotoxic concentration: > 10000 nM
Compound 3 gave a limit, no number (the forecaster's own chance of this, stated with the estimate: 75%); middle value at least 1.6-fold (0.22 log units) from the limit.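

In this assay compound 3 gives > 10000 nM, a limit of the assay and not a number, so neither its step from compound 1 nor its step from compound 2 can be read. The compounds shown leave open the concentration at which compound 1, compound 2 or compound 3 would reach half-maximal cytotoxicity, and whether the exchanged groups differ in their effect on it.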